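From Fluorophenyl to Phenylethenyl: An Expected Antiproliferative Shift

This account rests on a few compounds, and the source may have more. Where it says the series, first, only, none or still open, it means among the compounds named here.

Compound 1 `Nc1ncnn2c([C@@H]3O[C@H](CO)[C@@H](O)[C@H]3O)cc(C#Cc3ccccc3)c12`: in a functional assay on Z-138 cells (Homo sapiens) for antiproliferative activity, with a stated time of 72 h (on this read-out higher numbers stand for weaker inhibition and lower numbers for stronger inhibition), compound 1 gives 41400 nM
Compound 2 `Nc1ncnn2c([C@@H]3O[C@H](CO)[C@@H](O)[C@H]3O)cc(-c3ccccc3F)c12`: in this assay compound 2 gives 95300 nM

Among the measured compounds shown here, compound 2 has the highest of the two numbers, the only other point being compound 1, a step of a 2.3-fold higher number from compound 1 to compound 2 (0.36 log units; beyond the scatter). Compound 3 `Nc1ncnn2c([C@@H]3O[C@H](CO)[C@@H](O)[C@H]3O)cc(/C=C/c3ccccc3)c12` differs from compound 2 by 2-phenylethenyl in place of 2-fluorophenyl on an aromatic carbon. For the measured compounds named here, the one measured step that bears on this, a 2.3-fold higher number from compound 1 to compound 2 (0.36 log units; beyond the scatter), moved from a phenyl held off the ring by a link to a directly bound fluorophenyl; compound 3 returns to a linked phenyl, so the number is expected to fall back toward compound 1, a modest step of a 2.1-fold lower number from compound 2 to compound 3 (0.33 log units; beyond the scatter). Compound 3 is estimated at 45000 nM, with a range from 20000 nM to 110000 nM.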

Compound 3, half-maximal inhibitory concentration: 1300 nM
The estimate for compound 3 lay 35-fold (1.54 log units) above the measured number; the whole stated range lies above it.
By their numbers in this assay, from the lowest: compound 3; then compound 1; then compound 2.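

In this assay the 2-phenylethenyl group gives a 73-fold lower number from compound 2 to compound 3 (1.87 log units; beyond the scatter) and, against the 2-phenylethynyl group, a 32-fold lower number from compound 1 to compound 3 (1.50 log units; beyond the scatter) at this aromatic carbon. The earlier compounds shown here showed only a modest spread here, whereas this position now proves highly sensitive to the link that holds the phenyl, and a linked phenyl alone does not set the number, as compound 1 stays far above compound 3. Nothing given here explains this gap. Still open, from the compounds shown here alone, is whether 2-phenylethyl, with a saturated link, would keep this gain. Also open, going by these compounds, is how an amine or a nitrile on the phenyl of compound 3 would shift the number.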